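The source may report more compounds than this note shows. Statements on the series, on what has been measured and on what is new or still open speak of the compounds shown alone.

Compound 1 `COc1ccccc1/C=C/C(=O)OC/C=C/c1cc(OC)c(OC)cc1OC` and compound 2 `COc1cc(OC)c(OC)cc1/C=C/COC(=O)/C=C/c1ccc(OC)c(OC)c1` share one core. In a functional assay on the whole organism (strain Kunming) with Mus musculus as the target, with a stated time of 0.5 h, at a dose of 300 mg/kg by the intraperitoneal route (on this read-out lower numbers stand for a stronger effect and higher numbers for a weaker effect at the one dose given), compound 1 gives 100%, and compound 2 gives 100%, so compound 2 stands level with compound 1, the step of no change at the digits printed from compound 1 to compound 2 (within the scatter) staying within the scatter. Compound 3 `COc1cc(OC)c(OC)cc1/C=C/COC(=O)/C=C/c1ccc(Br)cc1` differs from compound 2 by 4-bromophenyl in place of 3,4-dimethoxyphenyl on a double-bonded chain carbon bound to a double-bonded chain carbon. Within the data shown here, only that one step bears on this change, and it showed no movement; nothing measured speaks to a bromine. The expected step of no change at the digits printed from compound 2 to compound 3 (within the scatter) is therefore none beyond the scatter. Compound 3 is expected to give 100%, within 70% to 100%.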

Compound 3, a percentage reported as activity, at one dose (the size of the read-out at that dose, not a potency): 100%
Compound 3: middle estimate and measured number agree at the digits printed; the measured number falls inside the stated range.
By their numbers in this assay, from the lowest: compounds 1, 2 and 3 (each within the scatter of the next).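

In this assay the swap to a bromine-bearing ring gives no change at the digits printed from compound 2 to compound 3 (within the scatter), so a phenyl carrying no methoxy group at all reads the same as the dimethoxy one at this place. Set against the 2-methoxyphenyl of the first compound, it gives no change at the digits printed from compound 1 to compound 3 (within the scatter), which extends the flat picture to a third group. Nothing available explains this sameness.

Going by these compounds, with all three compounds level, it stays open whether any group here can move the read-out. An amine or a carboxylic acid on this phenyl might answer that.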